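Shifting the hydroxyl-bearing chain on the sulfur of compound 1

This account rests on a few compounds, and the source may have more. Where it says the series, first, only, none or still open, it means among the compounds named here.

Measured compounds in a functional assay on HT cells (Homo sapiens) for antiproliferative activity, read by fluorescence, with a stated time of 72 h; on this read-out lower numbers stand for stronger inhibition of growth and higher numbers for weaker inhibition of growth:
compound 1, `CC(C)c1n[nH]c2c(NCc3ccc(-c4ccccn4)cc3)nc(SC(C)C(C)O)nc12`, 190 nM
compound 2, `CC(C)c1n[nH]c2c(NCc3ccc(-c4ccccn4)cc3)nc(SCC(C)(C)N)nc12`, 85 nM
compound 3, `CC(C)c1n[nH]c2c(NCc3ccc(-c4ccccn4)cc3)nc(SCCn3ccnc3)nc12`, 155 nM

Compound 1 has the highest number of the three. Among the measured compounds shown here, its nearest neighbour is compound 3, with a 1.2-fold lower number from compound 1 to compound 3 (0.09 log units; within the scatter); the only step beyond the scatter from it is a 2.2-fold lower number from compound 1 to compound 2 (0.35 log units; beyond the scatter). Compound 4, `CCC(O)CSc1nc(NCc2ccc(-c3ccccn3)cc2)c2[nH]nc(C(C)C)c2n1`, keeps the same atoms as compound 1 and differs only in how the chain on the sulfur is joined: 2-hydroxybutyl in place of 2-hydroxy-1-methylpropyl on a sulfur. For the measured compounds named here, no measured step bears directly on this change; both steps from compound 1 exchange the whole group rather than rearranging it, and one of them stays within the scatter. Compound 4 is therefore expected to show no step beyond the scatter, a 1.1-fold lower number from compound 1 to compound 4 (0.05 log units; within the scatter). The estimated value of compound 4 in this assay is 170 nM, within 80 nM to 400 nM.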

Compound 4, concentration for 50% growth inhibition: 273 nM
Compound 4: middle estimate off by 1.6-fold (0.21 log units), on the low side, and the stated range covers the measured number.
By their numbers in this assay, from the lowest: compounds 2, 3, 1 and 4 (each within the scatter of the next, the first and the last beyond it).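

In this assay the change from 2-hydroxy-1-methylpropyl to 2-hydroxybutyl on the sulfur, which keeps the same atoms, stays within the scatter (a 1.4-fold higher number from compound 1 to compound 4 (0.16 log units; within the scatter)). Compound 4 is also not separated from the imidazole-bearing chain (a 1.8-fold higher number from compound 3 to compound 4 (0.25 log units; within the scatter)), whereas the amino-bearing chain stands apart from it (a 3.2-fold higher number from compound 2 to compound 4 (0.51 log units; beyond the scatter)). No measurement shown accounts for these differences. From the compounds shown here alone, whether the separation of compound 2 from compound 4 belongs to its amine or to its branched chain stays open, as does the effect of a carboxylic acid or a longer chain on the sulfur.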